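This account rests on a few compounds, and the source may have more. Where it says the series, first, only, none or still open, it means among the compounds named here.

Two compounds built on the shared core frame this step, and neither offers a firm number. In a functional assay on A2780 cells (Homo sapiens) for antiproliferative activity, read by resazurin assay, with a stated time of 72 h (on this read-out higher numbers stand for weaker inhibition and lower numbers for stronger inhibition), compound 1 `Cc1ccccc1Cc1n[nH]c2cc(O)c(C(=O)N(C)Cc3ccccc3)cc12` has the result "not determined" (no result reported), so it gives no guidance. Compound 2 `Cc1cccc(Cc2n[nH]c3cc(O)c(C(=O)NCc4ccccc4)cc23)c1` reads > 10000 nM in this assay, and this is a limit of the assay rather than a number.

Compound 3 `Cc1cccc(Cc2n[nH]c3cc(O)c(C(=O)N(C)Cc4ccccc4Br)cc23)c1` differs from compound 2 on a carbonyl carbon, where benzylamino leaves and a group with no common name enters: a group of 10 heavy atoms (8 carbon, 1 nitrogen, 1 bromine; one six-membered aromatic ring of carbon only) in place of a group of 8 heavy atoms (7 carbon, 1 nitrogen; one six-membered aromatic ring of carbon only), on a carbonyl carbon. Going by the values given here, no measured pair shows what such a swap does, so any forecast is loose. A modest gain in strength in this assay seems likely, only somewhat beyond the usual scatter, though compound 3 may also end up reported only as a limit. The estimated change is an at least 1.6-fold lower number from compound 2 to compound 3 (0.22 log units; that floor lies within the scatter). For compound 3 the expected value is 6000 nM, with an estimated range of 1500 nM to 20000 nM.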

Compound 3, half-maximal inhibitory concentration: 310 nM
The estimate for compound 3 lay 19-fold (1.29 log units) above the measured number; measured number outside the range, below it.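

Going by these compounds alone, compound 3 gives the first firm number on the shared core, 310 nM in this assay, which shows that the group on this carbonyl carbon can decide whether the series registers at all in this assay. The swap gives an at least 32-fold lower number from compound 2 to compound 3 (1.50 log units; beyond the scatter), a large change for one group. Compound 2 reads > 10000 nM, which is a limit and not a number, so the step is a floor and its true size cannot be read: the limit of > 10000 nM in this assay, at which 1 of the 3 values shown sits.

The entering group both brings a bromine and lacks the hydrogen-bond donor of benzylamino, and this single step cannot separate those two changes. From the compounds shown here alone, whether a chlorine or a methoxy group in place of the bromine would give a similar reading also stays open.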